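A few compounds are considered here, and "the series" means these few. Any claim that something is new, unique, unknown or untested is made for them only; others in the source may bear on it.

For the measured compounds named here, in a functional assay on SH-SY5Y cells (Homo sapiens) for cytotoxicity, read by MTT assay, with a stated time of 72 h (on this read-out higher numbers stand for weaker inhibition and lower numbers for stronger inhibition), compound 1 `O=C1c2c[n+]([O-])c3ccccc3c2C(=O)c2c1c1ccccc1n2CCCCn1ccnc1` gives 130 nM and holds the lower of the two numbers so far. Compound 2 `CC1(C)OC[C@H](Cn2cc(Cn3c4c(c5ccccc53)C(=O)c3c[n+]([O-])c5ccccc5c3C4=O)nn2)O1` gives 820 nM and stands beyond the scatter from it. Compound 3 `CCCN1CCN(CCCCn2c3c(c4ccccc42)C(=O)c2c[n+]([O-])c4ccccc4c2C3=O)CC1` has 4-propylpiperazin-1-yl in place of 1H-imidazol-1-yl on a saturated chain carbon, four bonds along the chain from an aromatic nitrogen with the rest unchanged. Going by the values given here, no measured pair shows this change, so the expectation is loose. The expected step of a 1.5-fold higher number from compound 1 to compound 3 (0.19 log units; within the scatter) points to a somewhat higher number in this assay and stays within the scatter. For compound 3 the estimate is 200 nM with an expected range from 60 nM to 700 nM on this measure.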

Compound 3, half-maximal inhibitory concentration: 3970 nM
Compound 3: middle estimate off by 20-fold (1.30 log units), on the low side, and the stated range ends below it.
By their numbers in this assay, from the lowest: compound 1; then compound 2; then compound 3.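

Working notes: the saturated chain carbon, four bonds along the chain from an aromatic nitrogen, is sensitive to the group it carries. In this assay, 4-propylpiperazin-1-yl in place of 1H-imidazol-1-yl gives a 31-fold higher number from compound 1 to compound 3 (1.48 log units; beyond the scatter) and this first single-place comparison shows that the shared core alone does not set the number. No available evidence accounts for this step.

The compounds shown leave open whether the step follows the six-membered non-aromatic ring or its propyl group. An unsubstituted piperazine or a morpholine at this position would help separate the two.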